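Working notes on compounds 1 to 3

The source may report more compounds than this note shows. Statements on the series, on what has been measured and on what is new or still open speak of the compounds shown alone.

Measured so far:
compound 1 `Cc1ccc(C(=O)Oc2ccc(Cl)cc2C(=O)Nc2ccc(Cl)c(Cl)c2)cc1`: > 50000 nM
compound 2 `O=C(Oc1ccc(Cl)cc1C(=O)Nc1ccc(C(F)(F)F)cc1)c1ccc([N+](=O)[O-])cc1`: > 50000 nM

In an ADME assay on HepG2 cells (Homo sapiens) for cytotoxicity, read by MTT assay, with a stated time of 72 h (a lower number here means a stronger inhibitor, a higher number a weaker inhibitor), compound 1 gives > 50000 nM, which is a limit of the assay and not a number. Compound 2 gives > 50000 nM in this assay, likewise a limit. Within the data shown here, compound 2 therefore stands at the limit, and the one further value shown sits there too (the limit of > 50000 nM in this assay, at which 2 of the 2 values shown sit). Among the measured compounds shown here, no step between measured compounds can be read, since both values are limits.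

Compound 3 `O=C(Oc1ccc(Cl)cc1C(=O)Nc1ccc(Cl)c(Cl)c1)c1ccc([N+](=O)[O-])cc1` differs from compound 2 by 3,4-dichlorophenyl in place of 4-(trifluoromethyl)phenyl on an amide-type nitrogen. Compound 1 carries the same 3,4-dichlorophenyl on its amide-type nitrogen and also sits at the limit. From compound 2 to compound 3 no step beyond the scatter is expected in this assay. The expected step is a number no higher from compound 2 to compound 3 (the limit leaves the size open). Compound 3 is expected to give about 50000 nM in this assay, with a range from 20000 nM to 100000 nM, and most probably to be reported once more only as a limit rather than as a number.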

Compound 3, half-maximal inhibitory concentration: > 50000 nM
Compound 3 was reported as a limit; the forecaster's own chance of this, stated with the estimate: 80%; the middle value lies on the limit itself.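

In this assay compound 3 gives > 50000 nM, a limit and not a number. Among these compounds, no step among compound 1, compound 2 and compound 3 can be read, since all three values are limits: the limit of > 50000 nM in this assay, at which 3 of the 3 values shown sit. The compounds shown leave open what number, if any, each would give in this assay, and whether either single change alters it.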